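A Second Fluorine on the Aryl Ring: Expected Potency

The compounds below may be only part of what the source reports. "The series", "measured", "known", "first", "only" and "open" are said of these compounds alone.

Going by the values given here, compound 2 `COc1cc(/C=C/c2ccc(NC(=O)/C=C/c3ccccc3F)cc2)cc(OC)c1` gives 2380 nM in a functional assay on MDA-MB-231 cells (Homo sapiens) for inhibition, read by MTT assay, with a stated time of 48 h (on this read-out higher numbers stand for weaker inhibition and lower numbers for stronger inhibition), the lower of the two numbers known, while compound 1 `COc1cc(/C=C/c2ccc(NC(=O)/C=C/c3cc(OC)c(O)c(OC)c3)cc2)cc(OC)c1` gives 7130 nM. Among the compounds with values here, the one measured step, a 3.0-fold lower number from compound 1 to compound 2 (0.48 log units; beyond the scatter), swapped the whole aryl group at once. Compound 3 `COc1cc(/C=C/c2ccc(NC(=O)/C=C/c3ccc(F)cc3F)cc2)cc(OC)c1` differs from compound 2 only by fluoro in place of hydrogen on an aromatic carbon. Within the data shown here, no measured step adds a single fluorine, so the earlier swap is only a loose guide, and no step beyond the scatter is expected. The expected step is a 1.2-fold lower number from compound 2 to compound 3 (0.08 log units; within the scatter). Compound 3 is estimated at 2000 nM, within a range from 900 nM to 4500 nM.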

Compound 3, half-maximal inhibitory concentration: > 20000 nM
Compound 3 gave a limit, no number; the forecaster's own chance of this, stated with the estimate: 3%; at least 10-fold (1.00 log units) between middle value and limit.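

A single fluoro on this aromatic carbon, para to a large group and meta to the existing fluoro, is not a minor change here: the result is an at least 8.4-fold higher number from compound 2 to compound 3 (0.92 log units; beyond the scatter). The 2,4-difluorophenyl group also falls behind the 4-hydroxy-3,5-dimethoxyphenyl group, with an at least 2.8-fold higher number from compound 1 to compound 3 (0.44 log units; beyond the scatter). Compound 3 has a limit rather than a number: the limit of > 20000 nM in this assay, at which 1 of the 3 values shown sits.

From the compounds shown here alone, how far the true value of compound 3 lies beyond that limit remains open. So does whether a chloro or an amine on the same carbon would keep the level of compound 2.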